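This account rests on a few compounds, and the source may have more. Where it says the series, first, only, none or still open, it means among the compounds named here.

In a functional assay on HCT-116 cells (Homo sapiens) (on this read-out lower numbers stand for stronger inhibition of growth and higher numbers for weaker inhibition of growth), three compounds have been measured. Compound 1, with the structure `COc1ccccc1-c1cc(O)c2cc(C)cnc2n1`, gives 42700 nM in this assay. Compound 2, with the structure `Cc1cnc2nc(-c3ccc(F)cc3)cc(O)c2c1`, gives 24000 nM. Compound 3, with the structure `Cc1cc(C)c2c(O)cc(-c3ccc(Cl)cc3)nc2n1`, gives 14800 nM. Compound 1 therefore sits at the weak end of this small set: its number is higher than that of compound 3 by an amount beyond the usual scatter, while the gap between compound 1 and compound 2 falls within the scatter, so those two cannot be told apart.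

Compound 4, with the structure `COc1ccccc1-c1cc(O)c2cccnc2n1`, has not yet been measured. It is reached from compound 1 by a single change: hydrogen in place of methyl on an aromatic carbon. Among the compounds with values here, no pair of measured compounds shows this exact change, so nothing measured tells how large an effect to expect. Compound 2 and compound 3 differ from compound 1 in more than one place and cannot isolate it. In this assay the step from compound 1 to compound 4 is therefore expected to be small, a 1.2-fold higher number from compound 1 to compound 4 (0.07 log units; within the scatter), likely within the scatter. Compound 4 is estimated at 50000 nM, with a range from 20000 nM to 125000 nM.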

Compound 4, concentration for 50% growth inhibition: 27500 nM
Compound 4: middle estimate off by 1.8-fold (0.26 log units), on the high side; the range from low to high includes it.
By their numbers in this assay, from the lowest: compounds 3, 2, 4 and 1 (each within the scatter of the next, the first and the last beyond it).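

With hydrogen in place of methyl on this aromatic carbon, the change finally has a measured size: in this assay the step is a 1.6-fold lower number from compound 1 to compound 4 (0.19 log units; within the scatter) and so compound 1 and compound 4 cannot be told apart. The earlier compounds shown here could not show this, since each differs from compound 1 in more than one place; this pair shows that, on the core of compound 1, the growth-inhibition read-out stays within the scatter whether this carbon, two atoms from the ring nitrogen, carries a methyl or only a hydrogen. No separate measurement bears on what lies behind this result.

Going by these compounds, this is one step at one place on one core, so it remains open whether the same swap would also stay within the scatter on the cores of compound 2 or compound 3, which carry other aryl groups. On these data alone, it also remains open how this carbon would respond to something other than methyl or hydrogen, such as an ethyl chain, an amine or a carboxylic acid.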